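Swapping the Amine Substituent on the Shared Core

The source may report more compounds than this note shows. Statements on the series, on what has been measured and on what is new or still open speak of the compounds shown alone.

Among the measured compounds shown here, compound 2 `CC(C(=O)NCc1ccc(C(F)(F)F)nc1N1CCC(CN(C)C)CC1)c1ccc(NS(C)(=O)=O)c(F)c1` gives 426 nM in a functional assay on CHO-K1 cells for antagonist activity at transient receptor potential cation channel subfamily V member 1 (Homo sapiens), read by FLIPR (a lower number here means a stronger inhibitor, a higher number a weaker inhibitor), the higher of the two numbers recorded so far; its only neighbour, compound 1 `CC(C(=O)NCc1ccc(C(F)(F)F)nc1NC1CCCCC1)c1ccc(NS(C)(=O)=O)c(F)c1`, gives 260 nM. For the measured compounds named here, the single measured step, a 1.6-fold higher number from compound 1 to compound 2 (0.21 log units; within the scatter), exchanged the group on the same aromatic carbon and stayed within the scatter. Compound 3 `CC(C(=O)NCc1ccc(C(F)(F)F)nc1N1CCCCCCC1)c1ccc(NS(C)(=O)=O)c(F)c1` differs from compound 2 by a group of 8 heavy atoms (7 carbon, 1 nitrogen; one eight-membered non-aromatic ring with 1 hetero atom) in place of a group of 10 heavy atoms (8 carbon, 2 nitrogen; one six-membered non-aromatic ring with 1 hetero atom), on an aromatic carbon. Because a 1.6-fold higher number from compound 1 to compound 2 (0.21 log units; within the scatter) stayed within the scatter, compound 3 is expected to show a 1.4-fold lower number from compound 2 to compound 3 (0.15 log units; within the scatter), nothing beyond the scatter. Compound 3 is therefore estimated at 300 nM, in the range 110 nM to 800 nM.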

Compound 3, half-maximal inhibitory concentration: 27.8 nM
Beside the measured number, compound 3's estimate is 11-fold (1.03 log units) above it; the measured number lies below the stated range.
By their numbers in this assay, from the lowest: compound 3; then compounds 1 and 2 (each within the scatter of the next).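

Placing the eight-membered non-aromatic ring on this aromatic carbon gives a 15-fold lower number from compound 2 to compound 3 (1.19 log units; beyond the scatter) and a 9.4-fold lower number from compound 1 to compound 3 (0.97 log units; beyond the scatter). The position is thus not indifferent to its substituent, although the exchange between cyclohexylamino and 4-((dimethylamino)methyl)piperidin-1-yl had shown no change beyond the scatter. Nothing available accounts for this gain in potency.

The compounds shown leave open whether the gain belongs to the eight-membered ring alone or extends to smaller saturated rings on the same carbon. Unsubstituted piperidin-1-yl and azepan-1-yl would be the direct tests of that question.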